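The source may report more compounds than this note shows. Statements on the series, on what has been measured and on what is new or still open speak of the compounds shown alone.

Working notes on the series. Three compounds have numbers in a functional assay on the whole organism with Rattus norvegicus as the target, at a dose of 40 mg/kg by the intraperitoneal route; on this read-out lower numbers stand for less inhibition and higher numbers for more inhibition at the one dose given (going by the name of the read-out). Compound 1 `Cc1nc2c(Oc3ccccc3)cccn2c1N` gives 34% in this assay. Compound 2 `Cc1nc2c(OCc3ccccc3)cccn2c1CN` gives 46% in this assay. Compound 3 `CC(=O)Nc1c(C)nc2c(CCc3ccccc3)cccn12` gives 40% in this assay. On these numbers compound 2 stands apart from compound 1 by a gap beyond the scatter, while compound 3 lies within the scatter of compound 2, so no order between compound 2 and compound 3 can be read.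

Compound 4 `Cc1nc2c(OCc3ccccc3)cccn2c1NC(C)C` has not been measured in this assay. It differs from compound 2 as follows: isopropylamino in place of aminomethyl on an aromatic carbon. Among the measured compounds shown here, no measured pair shows this change, so its effect is unknown. The expected step from compound 2 to compound 4 in this assay is small, a number 6 percentage points lower from compound 2 to compound 4 (within the scatter), downward but not beyond the scatter. Compound 4 is therefore estimated at 40% in this assay, within 25% to 55%.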

Compound 4, a percentage reported as inhibition, in the whole organism at one dose (the size of the read-out at that dose, not a potency): 18%
Compound 4: the middle estimate sits 22 percentage points above what was measured; measured number outside the range, below it.
By their numbers in this assay, from the lowest: compound 4; then compounds 1, 3 and 2 (each within the scatter of the next, the first and the last beyond it).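

At the aromatic carbon of the five-membered ring, isopropylamino in place of aminomethyl gives a number 28 percentage points lower from compound 2 to compound 4 (beyond the scatter) in this assay. This first single-place comparison in the series shows that, with the rest of compound 2 held fixed, the group at this position can move the read-out beyond the scatter. Nothing measured here accounts for the step.

The step joins two changes in one: the larger group and the nitrogen now attached directly to the ring. Methylamino or aminoethyl at this position would begin to separate them.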